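The source may hold more compounds than are shown below. What is called first, only, known or untested is meant among the compounds shown, and "the series" means these compounds.

In a physicochemical assay for solubility (on this read-out lower numbers stand for lower solubility and higher numbers for higher solubility), compound 3 `O=C(O)c1ccc(C(=O)/C(=C\c2ccc(Br)c([N+](=O)[O-])c2)SCc2ccc(Cl)cc2)cc1` is known only as a limit, < 1000 ug/mL. Compound 2 `O=C(O)c1ccc(C(=O)/C(=C\c2ccc(Cl)c([N+](=O)[O-])c2)SCc2ccc(Cl)cc2)cc1` is also known only as a limit, < 1000 ug/mL. Within the data shown here, the series so far therefore offers only (the limit of < 1000 ug/mL in this assay, at which 3 of the 3 values shown sit), and no compound has yet given a number.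

Compound 4 `O=C(O)c1ccc(C(=O)/C(=C\c2ccc(Br)c([N+](=O)[O-])c2)SCc2ccc(Cl)cc2Cl)cc1` departs from compound 3 in a single place, where 4-chlorobenzyl becomes 2,4-dichlorobenzyl: chloro in place of hydrogen on an aromatic carbon. Among the measured compounds shown here, the one measured step nearby is a step that the two limits leave unreadable from compound 2 to compound 3, and it concerns bromo in place of chloro, not this change, so it gives no size to carry over. The closest guide is compound 1 `O=C(O)c1ccc(C(=O)/C(=C\c2ccc(F)c([N+](=O)[O-])c2)SCc2ccc(Cl)cc2Cl)cc1`, which carries the same 2,4-dichlorobenzyl group and is again a limit, < 1000 ug/mL.

No step beyond the scatter is expected in this assay, in either direction, and compound 4 will most likely be reported as a limit too. The expected step is a step that the limit leaves unreadable from compound 3 to compound 4. For compound 4 the estimated value is 500 ug/mL, with an expected range of 100 ug/mL to 1000 ug/mL.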

Compound 4, solubility: < 1000 ug/mL
Compound 4 ended at the assay's limit; the forecaster's own chance of this, stated with the estimate: 90%; the middle value lies beyond the limit too.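

Neither the comparison of compound 4 with compound 3 nor that with compound 1 can be read as a step in this assay: the limit of < 1000 ug/mL in this assay, at which 4 of the 4 values shown sit.

The compounds shown leave open what actual number any of them would give, and whether either change shifts that number at all.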